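Swapping a fluorophenyl amine for a benzyl amine

A few compounds are considered here, and "the series" means these few. Any claim that something is new, unique, unknown or untested is made for them only; others in the source may bear on it.

Three compounds share one core and differ in the group placed on a double-bonded ring carbon. Compound 1 `O=C1C(Nc2ccccc2F)=CC(=O)c2c1nc1n2[C@H]2OC[C@@H](O)[C@H]2OC1` carries a (2-fluorophenyl)amino group; in a functional assay on HeLa cells (Homo sapiens) for inhibition, read by sulforhodamine B assay (a higher number here means a weaker inhibitor, a lower number a stronger inhibitor), compound 1 gives 9820 nM, the higher of the two numbers obtained so far. Compound 3 `COc1ccccc1NC1=CC(=O)c2nc3n(c2C1=O)[C@H]1OC[C@@H](O)[C@H]1OC3` carries a (2-methoxyphenyl)amino group and gives 2950 nM in this assay, a gap to compound 1 that lies beyond the scatter. Compound 2 `O=C1C=C(N2CCC2)C(=O)c2c1nc1n2[C@H]2OC[C@@H](O)[C@H]2OC1` carries azetidin-1-yl; in this assay compound 2 reaches only a limit, > 16000 nM, so no number is known for it. Within the data shown here, the one measured step is an at least 5.4-fold lower number from compound 2 to compound 3 (0.73 log units; beyond the scatter), and its size rests on (the limit of > 16000 nM in this assay, at which 1 of the 3 values shown sits). Compound 4 `O=C1C(NCc2ccccc2)=CC(=O)c2c1nc1n2[C@H]2OC[C@@H](O)[C@H]2OC1` remains unmeasured. It differs from compound 1 in one place: benzyl in place of 2-fluorophenyl on an amine nitrogen. The measured step does not touch this kind of change, since it compares an amine closed into a small ring with an amine bound to an aromatic ring, whereas here the aromatic ring moves one carbon away from the nitrogen. With nothing bearing directly on a benzyl group, no step beyond the scatter is expected in either direction, though the uncertainty is wide. For compound 4 in this assay the estimate is 10000 nM, between 3000 nM and 30000 nM, meaning an expected step of a 1.0-fold higher number from compound 1 to compound 4 (0.01 log units; within the scatter).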

Compound 4, half-maximal inhibitory concentration: 11000 nM
Estimate against measurement, compound 4: 1.1-fold (0.04 log units) below; low and high end bracket the measured number.
By their numbers in this assay, from the lowest: compound 3; then compounds 1 and 4 (each within the scatter of the next). At a limit, above all of these: compound 2.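

In this assay, benzyl in place of 2-fluorophenyl on an amine nitrogen gives a 1.1-fold higher number from compound 1 to compound 4 (0.05 log units; within the scatter), so this change leaves no difference that can be told from the scatter of repeated measurements. The earlier step compared azetidin-1-yl with (2-methoxyphenyl)amino and rested on a limit for compound 2, so it gave only a minimum size for a change between very different groups; this step has a true number at both ends and compares two groups that each carry a six-membered aromatic ring of carbon only. It shows that, in this pair, the fluorine-bearing 2-fluorophenyl group and the all-carbon benzyl group cannot be separated at this position by this read-out, and nothing measured here bears on why the two read alike.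

The compounds shown leave open whether a 2-methoxybenzyl group on the same amine nitrogen would read like compound 4 or like compound 3, which gives 2950 nM. They also leave open how a longer chain ending in the same ring, such as 2-phenylethyl, or a plain ethyl group with no ring at all, would read in this assay.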